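Trifluoromethyl in Place of Ethyl on the Benzoate Ring

This account rests on a few compounds, and the source may have more. Where it says the series, first, only, none or still open, it means among the compounds named here.

Compound 2 `CCc1ccc(C(=O)OCCCc2cn(-c3ccnc4cc(Cl)ccc34)nn2)cc1` gives in an ADME assay on HepG2 cells (Homo sapiens) for cytotoxicity, read by MTT assay, with a stated time of 24 h (a lower number here means that less compound is tolerated, a higher number that more compound is tolerated), only a limit of the assay, > 2550000 nM. Compound 1 `O=C(OCCCc1cn(-c2ccnc3cc(Cl)ccc23)nn1)c1ccccc1`, carrying hydrogen on that aromatic carbon, gives 1200000 nM in this assay. Within the data shown here, the one measured step there, an at least 2.1-fold higher number from compound 1 to compound 2 (0.32 log units; beyond the scatter), is bounded by the limit (the limit of > 2550000 nM in this assay, at which 1 of the 2 values shown sits). Compound 3 `O=C(OCCCc1cn(-c2ccnc3cc(Cl)ccc23)nn1)c1ccc(C(F)(F)F)cc1` differs from compound 2 by trifluoromethyl in place of ethyl on an aromatic carbon. Among the measured compounds shown here, with only that one step to draw on, and it ending at the limit, a change no larger than the scatter is expected, an at least 1.0-fold lower number from compound 2 to compound 3 (0.00 log units; that floor lies within the scatter). For compound 3 the expected value in this assay is 2500000 nM, ranging from 1200000 nM to 5500000 nM.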

Compound 3, half-maximal cytotoxic concentration: > 2170000 nM
Compound 3 ended at the assay's limit (the forecaster's own chance of this, stated with the estimate: 55%); the middle value lies beyond the limit too.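

Trifluoromethyl on this aromatic carbon, like ethyl, leaves the read-out in this assay at a limit of the assay and not at a number: the limit of > 2170000 nM in this assay, at which 1 of the 3 values shown sits. The step between compound 2 and compound 3 cannot be read, so the two groups cannot be ranked here: the limit of > 2550000 nM in this assay, at which 1 of the 3 values shown sits. Set against hydrogen, trifluoromethyl gives an at least 1.8-fold higher number from compound 1 to compound 3 (0.25 log units; that floor lies within the scatter), so this limit alone does not separate compound 3 from compound 1 beyond the scatter.

Going by these compounds, how far compound 2 and compound 3 lie past their limits stays open. So does whether an amine or a carboxylic acid on this carbon would give a readable number in this assay.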